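The source may hold more compounds than are shown below. What is called first, only, known or untested is meant among the compounds shown, and "the series" means these compounds.

In a functional assay on PBMC cells (Homo sapiens) for inhibition, read by HTRF, with stated times of 15 min and 24 h (a lower number here means a stronger inhibitor, a higher number a weaker inhibitor), compound 1 `O=C(Nc1ccc2c(c1)B(O)OC2)c1ccccc1` gives > 100000 nM, which is a limit. Compound 2 `O=C(Nc1ccc2c(c1)B(O)OC2)c1ccccc1F` gives > 10000 nM, also a limit, so no number places it. Compound 3 `O=C(Nc1ccc2c(c1)B(O)OC2)c1ccccc1-c1ccccc1` carries phenyl in place of fluoro on an aromatic carbon, phenyl in place of fluoro on an aromatic carbon. Going by the values given here, the one measured step bearing on this touches the same aromatic carbon: a step that the two limits leave unreadable from compound 1 to compound 2. That gives neither size nor direction, so no readable step is expected in this assay, and weak inhibition is expected to persist. The expected step is a step that the limit leaves unreadable from compound 2 to compound 3. For compound 3 the estimated value is 30000 nM, with an expected range of 10000 nM to 100000 nM.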

Compound 3, half-maximal inhibitory concentration: > 100000 nM
Compound 3: a limit, no number (the forecaster's own chance of this, stated with the estimate: 75%); at least 3.3-fold (0.52 log units) between middle value and limit.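

In this assay, going by these compounds alone, compound 1, compound 2 and compound 3 all give limits, not numbers, so no step among them can be read. The compounds shown leave open whether any group on this aromatic carbon gives a readable inhibition value.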